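This account rests on a few compounds, and the source may have more. Where it says the series, first, only, none or still open, it means among the compounds named here.

In a functional assay for inhibition, with Rattus norvegicus as the target (a higher number here means a weaker inhibitor, a lower number a stronger inhibitor), compound 1 (`CCC(CC)/N=c1\c(O)c(O)\c1=N/c1ccc(C#N)cc1`) gives 3340 nM. Compound 2 (`CC(C)(C)C/N=c1\c(O)c(O)\c1=N/c1ccc(C#N)cc1`) gives > 30000 nM, which is a limit of the assay and not a number. Its true position is therefore unknown, and it stands only as a limit on the numbers shown.

Compound 3 (`CCCCCCC/N=c1\c(O)c(O)\c1=N/c1ccc(C#N)cc1`) has hexyl in place of tert-butyl on a saturated chain carbon bound to a double-bonded nitrogen, (hexyl in place of tert-butyl on a saturated chain carbon bound to a double-bonded nitrogen). Read one bond further out, this is neopentyl to heptyl.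

Among the measured compounds shown here, only one measured step bears on this change: an at least 8.9-fold higher number from compound 1 to compound 2 (0.95 log units; beyond the scatter). It shows that exchanging the group on that nitrogen can move the number in this assay beyond the scatter. For the measured compounds named here, no heptyl compound has been measured, so the size of the new step remains uncertain. Compound 3 is expected to return towards the level of compound 1 rather than stay at the limit, though it may well remain weaker. The expected change is an at least 5.0-fold lower number from compound 2 to compound 3 (0.69 log units; beyond the scatter), a move to a lower number. For compound 3 the estimate is 6000 nM, with an expected range from 1200 nM to 30000 nM.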

Compound 3, half-maximal inhibitory concentration: > 30000 nM
Compound 3: only a limit was reported; the forecaster's own chance of this, stated with the estimate: 25%; middle value at least 5.0-fold (0.69 log units) from the limit.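

In this assay compound 3 gives > 30000 nM, which is a limit of the assay and not a number. The change from pentan-3-yl to the straight heptyl chain gives an at least 8.9-fold higher number from compound 1 to compound 3 (0.95 log units; beyond the scatter), so the loss seen with neopentyl is not confined to that branched group, and of the three groups shown on the double-bonded nitrogen only the pentan-3-yl of compound 1 gives a readable number. The step between compound 2 and compound 3 cannot be read, and hexyl in place of tert-butyl cannot be ranked, because both compounds sit at the same limit: the limit of > 30000 nM in this assay, at which 2 of the 3 values shown sit.

The compounds shown leave open where the true values of compound 2 and compound 3 lie, and so whether the longer chain differs at all from neopentyl. They also leave open whether a shorter chain such as propyl, a ring such as cyclopentyl, or a chain carrying an amine would give a readable number in this assay, and how any of these would stand against compound 1.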